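Hydrazone series on a shared core: moving to 2-nitrophenyl

The source may report more compounds than this note shows. Statements on the series, on what has been measured and on what is new or still open speak of the compounds shown alone.

Measured so far in a functional assay on HepG2 cells (Homo sapiens) for cytotoxicity, read by MTT assay, with a stated time of 48 h; a lower number here means a stronger inhibitor, a higher number a weaker inhibitor:
compound 1, `O=C(CSc1nnc(-c2ccncc2)o1)N/N=C/c1ccccc1`, 17300 nM
compound 2, `O=C(CSc1nnc(-c2ccncc2)o1)N/N=C/c1ccc(F)cc1`, 12300 nM
compound 3, `COc1ccc(/C=N/NC(=O)CSc2nnc(-c3ccncc3)o2)cc1`, 15800 nM

Compound 3 sits second highest of the three numbers; its nearest neighbour is compound 1 and its furthest compound 2, both within the scatter. Within the data shown here, the steps that bear on the aryl group are a 1.4-fold lower number from compound 1 to compound 2 (0.15 log units; within the scatter), a 1.1-fold lower number from compound 1 to compound 3 (0.04 log units; within the scatter) and a 1.3-fold higher number from compound 2 to compound 3 (0.11 log units; within the scatter), none of them beyond the scatter. Compound 4, `O=C(CSc1nnc(-c2ccncc2)o1)N/N=C/c1ccccc1[N+](=O)[O-]`, differs from compound 3 by 2-nitrophenyl in place of 4-methoxyphenyl on a carbon with a double bond to nitrogen. Among the measured compounds shown here, no measured step covers a nitro group or this position, so the change is larger than any step seen, but the series so far shows the aryl substituent moving the number little. Compound 4 is therefore expected to give about 15000 nM, with a range of 7000 nM to 32000 nM, a step of a 1.1-fold lower number from compound 3 to compound 4 (0.02 log units; within the scatter) that is expected to stay within the scatter.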

Compound 4, half-maximal inhibitory concentration: 24700 nM
For compound 4 the middle estimate is 1.6-fold (0.22 log units) below the measured one, within the range that was stated.
By their numbers in this assay, from the lowest: compounds 2, 3, 1 and 4 (each within the scatter of the next).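

Working from the core of compound 1 in this assay, the nitro group gives a 1.4-fold higher number from compound 1 to compound 4 (0.15 log units; within the scatter) while the aryl exchanges give a 1.6-fold higher number from compound 3 to compound 4 (0.19 log units; within the scatter) and a 2.0-fold higher number from compound 2 to compound 4 (0.30 log units; within the scatter) with all three printed as within the scatter. On the carbon with a double bond to nitrogen, 2-nitrophenyl therefore joins the other aryl groups with no step beyond the scatter, so the flat picture across compounds 1 to 4 now includes a nitro group. No evidence on the cause of these numbers is available.

Still open, on these data alone, is whether an amine or a carboxylic acid on the phenyl ring, or a longer chain in place of the aryl group, would give a step beyond the scatter. Also open, as far as these compounds go, is whether the nitro result holds with that group elsewhere on the ring.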